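Propyl in place of dimethylaminophenyl: series notes

The source may hold more compounds than are shown below. What is called first, only, known or untested is meant among the compounds shown, and "the series" means these compounds.

Compound 1 `CC(=O)OC[C@H]1O[C@@H](n2cc(CN3C(=O)/C(=C\c4ccc(N(C)C)cc4)c4ccccc43)nn2)[C@H](OC(C)=O)[C@@H](OC(C)=O)[C@@H]1OC(C)=O` and compound 2 `CC(=O)OC[C@H]1O[C@@H](n2cc(CN3C(=O)/C(=C/c4ccc(N(C)C)cc4)c4ccccc43)nn2)[C@H](OC(C)=O)[C@@H](OC(C)=O)[C@@H]1OC(C)=O` share one framework and differ only in the configuration drawn at the exocyclic double bond. In a functional assay on HeLa cells (Homo sapiens) for cytotoxicity, read by sulforhodamine B assay, with a stated time of 48 h (a lower number here means a stronger inhibitor, a higher number a weaker inhibitor), compound 1 gives 25000 nM, and compound 2 gives 26300 nM; the step of a 1.1-fold higher number from compound 1 to compound 2 (0.02 log units; within the scatter) is within the scatter, consistent with the fact that the two compounds differ only in drawn configuration (the fact that compounds 1 and 2 differ only in the configuration as drawn). Compound 2 stands at the highest of the two numbers, with compound 1 as its nearest neighbour within the scatter.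

Compound 3 `CCC/C=C1/C(=O)N(Cc2cn([C@@H]3O[C@H](COC(C)=O)[C@@H](OC(C)=O)[C@H](OC(C)=O)[C@H]3OC(C)=O)nn2)c2ccccc21` carries the change (propyl in place of 4-(dimethylamino)phenyl on a double-bonded chain carbon bound to a double-bonded ring carbon). Within the data shown here, no measured step touches this replacement; the only measured step, from compound 1 to compound 2, concerned drawn geometry alone and lay within the scatter, so it gives no guide. Loss of the aromatic ring is a large structural change, and a weaker number is expected for compound 3, the expected step being a 2.3-fold higher number from compound 2 to compound 3 (0.36 log units; beyond the scatter) in this assay. Compound 3 is therefore estimated at 60000 nM, within a range from 15000 nM to 200000 nM.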

Compound 3, half-maximal inhibitory concentration: > 100000 nM
Compound 3: only a limit was reported; the forecaster's own chance of this, stated with the estimate: 40%; middle value at least 1.6-fold (0.22 log units) from the limit.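

The step between compound 1 and compound 2 only tested drawn geometry, and it stayed within the scatter with 4-(dimethylamino)phenyl in place: a 1.1-fold higher number from compound 1 to compound 2 (0.02 log units; within the scatter). Replacing the group itself on a double-bonded chain carbon bound to a double-bonded ring carbon does register, with propyl giving an at least 3.8-fold higher number from compound 2 to compound 3 (0.58 log units; beyond the scatter), so this position responds to the identity of the group in a way the geometry change did not show. Compound 3 gives > 100000 nM in this assay, which is a limit of the assay and not a number: the limit of > 100000 nM in this assay, at which 1 of the 3 values shown sits.

The compounds shown do not separate the aromatic ring from its dimethylamino group, and a plain phenyl at this place would bear on that question. Going by these compounds, how a longer chain such as hexyl, or a chain ending in an amine, would read compared with propyl also remains open.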